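A second methoxy added to the aryl ring of compound 1

This account rests on a few compounds, and the source may have more. Where it says the series, first, only, none or still open, it means among the compounds named here.

Measured compounds:
compound 1, `COc1ccccc1/C=C1\CN(CC(=O)O)c2c(C)cccc2C1=O`: in an assay on HL-60 cells for inhibition of glutathione S-transferase P (Homo sapiens), read by spectrophotometry, tested at 20 uM (on this read-out lower numbers stand for less inhibition and higher numbers for more inhibition at the one concentration tested (going by the name of the read-out)), compound 1 gives 4.72%
compound 2, `Cc1cccc2c1N(CC(=O)O)C/C(=C\c1ccc(F)cc1)C2=O`: compound 2 gives 22.9%
compound 3, `CCOc1ccccc1/C=C1\CN(CC(=O)O)c2c(Cl)cccc2C1=O`: compound 3 gives 19.7%

Compound 1 stands lowest of the three numbers. Its nearest neighbour is compound 3, with a number beyond the scatter above it, and the furthest is compound 2. Within the data shown here, the one step measured between compounds that differ in a single place, a number 18.2 percentage points higher from compound 1 to compound 2 (beyond the scatter), is modest and beyond the scatter, but it replaces the whole aryl group rather than adding to it, so it bears only loosely on the present question.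

Compound 4, `COc1ccc(OC)c(/C=C2\CN(CC(=O)O)c3c(C)cccc3C2=O)c1`, differs from compound 1 by methoxy in place of hydrogen on an aromatic carbon, that is, a methoxy group entering on an aromatic carbon meta to a large group and para to a methoxy group. Among the measured compounds shown here, no measured step adds a methoxy group in this way, so the expectation rests on the low number of compound 1 and on the fact that every measured change away from it moved upward. Compound 4 is therefore expected to show a small rise, a number 5.3 percentage points higher from compound 1 to compound 4 (within the scatter), likely within or only just beyond the scatter, with an estimated value of 10%, ranging from 0% to 25%.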

Compound 4, a percentage reported as inhibition, at one concentration (the size of the read-out at that concentration, not a potency): 5.44%
For compound 4 the middle estimate is 4.6 percentage points above the measured one, within the range that was stated.
By their numbers in this assay, from the lowest: compounds 1 and 4 (each within the scatter of the next); then compounds 3 and 2 (each within the scatter of the next).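

In this assay, methoxy in place of hydrogen on an aromatic carbon, meta to a large group and para to a methoxy group, gives a number 0.7 percentage points higher from compound 1 to compound 4 (within the scatter), so the two compounds cannot be told apart. Among these compounds, the earlier step, a number 18.2 percentage points higher from compound 1 to compound 2 (beyond the scatter), had replaced the whole aryl group, whereas this addition to the 2-methoxyphenyl ring is the first single change from compound 1 that stays within the scatter. Nothing measured here gives a reason for this result.

As far as these compounds go, whether an amine or a hydroxyl group on this same aromatic carbon would stand apart from compound 1 remains open. So does whether a methoxy group added to the 4-fluorophenyl ring of compound 2 would likewise leave the number within the scatter.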